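Phenyl in Place of Iodo on Two Related Cores

The source may report more compounds than this note shows. Statements on the series, on what has been measured and on what is new or still open speak of the compounds shown alone.

In a functional assay on CEM-DNR-bulk cells (Homo sapiens), read by MTT assay, with a stated time of 72 h (on this read-out lower numbers stand for stronger inhibition and higher numbers for weaker inhibition), compound 2 `Cc1nc(N)c2c(I)cn([C@@H]3O[C@H](CO)[C@@H](O)[C@H]3O)c2n1` gives 3480 nM. Compound 1 `Cc1nc(N)c2c(-c3ccccc3)cn([C@@H]3O[C@H](CO)[C@@H](O)[C@H]3O)c2n1` differs by phenyl in place of iodo on an aromatic carbon. For compound 1 the assay returns only a limit, > 20000 nM. The step of an at least 5.7-fold higher number from compound 2 to compound 1 (0.75 log units; beyond the scatter) thus weakened inhibition. Compound 3 `CNc1ncnc2c1c(I)cn2[C@@H]1O[C@H](CO)[C@@H](O)[C@H]1O` has a different core from compound 2; the difference between the two cores is not broken down here. For compound 3 the assay likewise returns only a limit, > 20000 nM. Compound 4 `CNc1ncnc2c1c(-c1ccccc1)cn2[C@@H]1O[C@H](CO)[C@@H](O)[C@H]1O` has not been measured; it differs from compound 3 by phenyl in place of iodo on an aromatic carbon, the same change at the same place as between compound 2 and compound 1. Since compound 3 already sits at the limit of > 20000 nM in this assay, at which 2 of the 3 values shown sit, and the earlier step of an at least 5.7-fold higher number from compound 2 to compound 1 (0.75 log units; beyond the scatter) raised the number, compound 4 is expected to stay there, with an estimated step that the limit leaves unreadable from compound 3 to compound 4. Compound 4 is estimated at 50000 nM, expected between 15000 nM and 300000 nM.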

Compound 4, half-maximal inhibitory concentration: > 20000 nM
Compound 4: no number, only a limit; the forecaster's own chance of this, stated with the estimate: 85%; the middle value does not contradict the limit.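

No step can be read from compound 3 to compound 4, because both return a limit rather than a number: the limit of > 20000 nM in this assay, at which 3 of the 4 values shown sit.

From the compounds shown here alone, whether phenyl in place of iodo changes inhibition at all on the core of compound 3 stays open.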